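The source may report more compounds than this note shows. Statements on the series, on what has been measured and on what is new or still open speak of the compounds shown alone.

Compound 3 `COc1cc(-c2ccnc3cc(-c4cn(C)c5ccccc45)nn23)cc(OC)c1OC` is examined in a functional assay on MCF7 cells (Homo sapiens) for inhibition, read by CCK-8 assay, with a stated time of 48 h (on this read-out lower numbers stand for stronger inhibition and higher numbers for weaker inhibition), where compound 3 gives 95 nM. Among the three compounds measured so far, compound 3 stands second highest. Compound 1 `COc1cc(-c2ccnc3cc(-c4ccc(C)cc4)nn23)cc(OC)c1OC` gives 47 nM in this assay, and compound 2 `COc1cc(-c2ccnc3cc(-c4ccc(C(C)=O)cc4)nn23)cc(OC)c1OC` gives 5230 nM. The nearest neighbour of compound 3 is compound 1, through the step of a 2.0-fold higher number from compound 1 to compound 3 (0.31 log units; beyond the scatter); the furthest is compound 2, through the step of a 55-fold lower number from compound 2 to compound 3 (1.74 log units; beyond the scatter).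

The next compound, compound 4 `COc1cc(-c2ccnc3cc(-c4ccc(F)cc4)nn23)cc(OC)c1OC`, differs from compound 3 in one place: 4-fluorophenyl in place of 1-methyl-1H-indol-3-yl on an aromatic carbon. Among the compounds with values here, the step that bears most directly on this is the one from compound 1 to compound 3, a modest one of a 2.0-fold higher number from compound 1 to compound 3 (0.31 log units; beyond the scatter), which shows that a 4-methylphenyl and a 1-methyl-1H-indol-3-yl on this carbon give numbers only just outside the scatter of each other. Within the data shown here, the step of a 110-fold higher number from compound 1 to compound 2 (2.05 log units; beyond the scatter) shows that a change of the group on the phenyl ring can move the number a great deal, but acetyl is a larger group than fluorine and nothing measured so far speaks to a 4-fluorophenyl. Given that compound 1 gives 47 nM, compound 4 is expected to come in close to compound 1, and the step to compound 4 is estimated as a 1.6-fold lower number from compound 3 to compound 4 (0.20 log units; within the scatter), within the scatter. Compound 4 is therefore estimated at 60 nM, with a range from 15 nM to 300 nM.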

Compound 4, half-maximal inhibitory concentration: 1280 nM
The estimate for compound 4 lay 21-fold (1.33 log units) below the measured number, and the stated range ends below it.
By their numbers in this assay, from the lowest: compound 1; then compound 3; then compound 4; then compound 2.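

Within the substituted phenyl series in this assay, fluoro in place of methyl is a large step, a 27-fold higher number from compound 1 to compound 4 (1.44 log units; beyond the scatter), so the low number of compound 1 does not carry over to this other small group on the phenyl ring. Fluoro in place of acetyl is a much smaller step, a 4.1-fold lower number from compound 2 to compound 4 (0.61 log units; beyond the scatter), which places compound 4 nearer to compound 2 than to compound 1 and leaves the methyl-bearing compound 1 alone at the low end among these three phenyl compounds. The step of a 13-fold higher number from compound 3 to compound 4 (1.13 log units; beyond the scatter) adds that the closeness of compound 3 to compound 1 does not extend to every aromatic group on this carbon, since 4-fluorophenyl and 1-methyl-1H-indol-3-yl are far apart here.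

Nothing at hand accounts for any of these steps. From the compounds shown here alone, it remains open whether an ethyl group, a methoxy group, a chlorine atom or an amine on the phenyl ring would give a number close to that of compound 1 or one closer to those of compound 2 and compound 4.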